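The source may report more compounds than this note shows. Statements on the series, on what has been measured and on what is new or still open speak of the compounds shown alone.

Measured so far in an ADME assay on HCT-116 cells (Homo sapiens) for cytotoxicity, read by CellTiter-Glo, with a stated time of 72 h; a higher number here means a weaker inhibitor, a lower number a stronger inhibitor:
- compound 1 `CC1CCN(C2CCN(S(=O)(=O)c3nccn3C)CC2)CC1`: > 10000 nM, a limit
- compound 2 `CC1CCN(C2CCN(S(=O)(=O)c3ccc(-c4ccc(Cl)cc4)cc3)CC2)CC1`: > 5000 nM, a limit
- compound 3 `Cc1nc(Cl)sc1S(=O)(=O)N1CCC(N2CCC(C)CC2)CC1`: > 10000 nM, a limit

For the measured compounds named here, no compound has yet given a number in this assay. Compound 3 sits at the limit of > 10000 nM in this assay, at which 2 of the 3 values shown sit. Compound 2 sits at the limit of > 5000 nM in this assay, at which 1 of the 3 values shown sits.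

Compound 4 `CCc1ccc(S(=O)(=O)N2CCC(N3CCC(C)CC3)CC2)cc1` carries 4-ethylphenyl in place of 2-chloro-4-methyl-1,3-thiazol-5-yl on a sulfonyl sulfur. Going by the values given here, the only measured step at this place is a step that the two limits leave unreadable from compound 1 to compound 3. It gives no size to carry over. Compound 2 adds no size either, as its > 5000 nM is also a limit.

With no readable step to draw on, no change beyond the scatter is expected in this assay, and no direction can be assigned. Compound 3 is itself a limit at > 10000 nM, so compound 4 is expected to be reported as a limit as well. The expected step is a number no higher from compound 3 to compound 4 (the limit leaves the size open). The estimate for compound 4 is 10000 nM, with an expected range of 4000 nM to 25000 nM.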

Compound 4, half-maximal inhibitory concentration: > 5000 nM
Compound 4: a limit, no number; the forecaster's own chance of this, stated with the estimate: 85%; the middle value lies beyond the limit too.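

All four compounds stand as limits in this assay, so the steps from compound 1, compound 2 and compound 3 to compound 4 cannot be read. The compounds shown leave open whether any group on the sulfonyl sulfur gives a number in this assay, and how large any difference between them would be.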